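Halogen Removal and Cytotoxicity in a Small Analogue Set

This account rests on a few compounds, and the source may have more. Where it says the series, first, only, none or still open, it means among the compounds named here.

Measured in a functional assay on A549 cells (Homo sapiens) for cytotoxicity, read by MTT assay, with a stated time of 24 h; a lower number here means a stronger inhibitor, a higher number a weaker inhibitor:
compound 1, `O=c1nc2ccc(Br)cn2cc1Cc1ccc(Cl)cc1`, gives 105000 nM;
compound 2, `O=c1nc2ccc(Cl)cn2cc1Cc1ccc(F)cc1`, gives 98300 nM;
compound 3, `O=c1nc2ccc(Br)cn2cc1Cc1ccccc1`, reaches only the assay limit of > 1000000 nM.

Compound 1 and compound 2 differ in more than one place, and the difference between their two cores is not broken down here. Compound 1 and compound 2 lie within the usual scatter of each other. Going from compound 1 to compound 3 the change is hydrogen in place of chloro on an aromatic carbon, and the step is an at least 9.5-fold higher number from compound 1 to compound 3 (0.97 log units; beyond the scatter), one of the values being (the limit of > 1000000 nM in this assay, at which 1 of the 3 values shown sits).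

Compound 4, `O=c1nc2ccccn2cc1Cc1ccc(F)cc1`, is not yet measured. From compound 2 it differs by hydrogen in place of chloro on an aromatic carbon. This is the same kind of change as from compound 1 to compound 3, but at a different place: on a six-membered aromatic ring with one nitrogen within a fused or bridged system of two rings, rather than on a ring of carbon only para to a large group. For compound 4 the step expected is a 3.1-fold higher number from compound 2 to compound 4 (0.48 log units; beyond the scatter), resting on compound 2 at 98300 nM and on the weakening seen in an at least 9.5-fold higher number from compound 1 to compound 3 (0.97 log units; beyond the scatter). Compound 4 is thus estimated at 300000 nM, expected between 90000 nM and 1000000 nM.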

Compound 4, half-maximal inhibitory concentration: > 1000000 nM
Compound 4: a limit, no number; the forecaster's own chance of this, stated with the estimate: 35%; middle value at least 3.3-fold (0.52 log units) from the limit.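

In this assay compound 4 reaches only a limit of the assay, > 1000000 nM, not a number. Replacing the chloro with hydrogen gives an at least 10-fold higher number from compound 2 to compound 4 (1.00 log units; beyond the scatter), so the change weakens the compound on both cores, even though it sits on a different ring in each: the same change on two cores in this assay, an at least 9.5-fold higher number (0.97 log units; beyond the scatter) from compound 1 to compound 3 and an at least 10-fold higher number (1.00 log units; beyond the scatter) from compound 2 to compound 4; the limit leaves it open whether they differ. This does not show that the loss is equally large in both cases, since neither step has a measured end point: the limit of > 1000000 nM in this assay, at which 2 of the 4 values shown sit.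

Still open, on these data alone, is whether a different group in the chloro's place, such as an amine or a methoxy group, would keep a measurable number in this assay. Also open, as far as these compounds go, is whether a longer chain in place of the halogen would do the same.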